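The source may report more compounds than this note shows. Statements on the series, on what has been measured and on what is new or still open speak of the compounds shown alone.

Measured so far:
compound 1, `COc1ccc(Cn2c(-c3ccccc3)c(-c3ccccc3)c3c(=N)n(CCO)cnc32)cc1`, in an ADME assay for permeability, using PAMPA, with a stated time of 30 min, at pH 7.4; a lower number here means that the compound crosses the layer more slowly, a higher number that the compound crosses the layer faster: > 1000 10^-6 cm/s
compound 2, `N=c1c2c(-c3ccccc3)c(-c3ccccc3)n(Cc3ccccc3)c2ncn1C1CCN(Cc2ccccc2)CC1`, in this assay: "nd" (no result reported)

In this assay compound 1 gives > 1000 10^-6 cm/s, which is a limit of the assay and not a number. For compound 2 this assay records "nd" (no result reported), so no number stands beside it. Compound 3, `COc1ccc(Cn2c(-c3ccccc3)c(-c3ccccc3)c3c(=N)n(CCCO)cnc32)cc1`, differs from compound 1 by hydroxymethyl in place of hydroxy on a saturated chain carbon, two bonds along the chain from an aromatic nitrogen. Among the measured compounds shown here, no measured pair shows this change. Because compound 1 already sits at the limit of > 1000 10^-6 cm/s in this assay, at which 1 of the 2 values shown sits, compound 3 is expected to sit there too, and the expected step that the limit leaves unreadable from compound 1 to compound 3 is none beyond the scatter. Compound 3 is estimated at 1200 10^-6 cm/s, between 600 10^-6 cm/s and 2500 10^-6 cm/s.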

Compound 3, apparent permeability: > 1000 10^-6 cm/s
Compound 3 ended at the assay's limit; the forecaster's own chance of this, stated with the estimate: 80%; the middle value is on the limit's open side.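

Compound 1 and compound 3 both stand at a limit of the assay, so no step between them can be read: the limit of > 1000 10^-6 cm/s in this assay, at which 2 of the 3 values shown sit.

In this assay the compounds shown leave open whether the 2-hydroxyethyl chain and the 3-hydroxypropyl chain differ at all.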